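Fluoro-to-hydrogen step in a melanocortin receptor 4 series

This account rests on a few compounds, and the source may have more. Where it says the series, first, only, none or still open, it means among the compounds named here.

Measured so far, in a functional assay on CHO cells for agonist activity at Melanocortin receptor 4 (Homo sapiens), read by a luciferase reporter, with a stated time of 4 h; a higher number here means that more compound is needed for the effect, a lower number that less compound is needed:
compound 1, `CC(C)N(C(=O)CN1C=CN(c2ccccc2)C(=O)[C@H](Cc2n[nH]c3ccccc23)C1=O)c1ccccc1`, gives 1070 nM;
compound 2, `O=C1C(Cc2n[nH]c3cc(F)ccc23)C(=O)N(c2ccccc2)C=CN1CC(=O)N1CCCCc2ccccc21`, gives 437 nM;
compound 3, `CC(C)N(C(=O)CN1C=CN(c2ccccc2)C(=O)[C@H](Cc2n[nH]c3cc(F)ccc23)C1=O)c1ccccc1`, gives 1260 nM.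

Compound 2 gives the lowest number of the three, and the gaps to compound 1 and to compound 3 both lie beyond the scatter of this assay. Compound 2 and compound 3 carry different cores, and the difference between the two cores is not broken down here.

Compound 3 and compound 1 differ in one place only, (hydrogen in place of fluoro on an aromatic carbon), and this change gave a 1.2-fold lower number from compound 3 to compound 1 (0.07 log units; within the scatter). Compound 4, `O=C1C(Cc2n[nH]c3ccccc23)C(=O)N(c2ccccc2)C=CN1CC(=O)N1CCCCc2ccccc21`, has not yet been measured; it differs from compound 2 by hydrogen in place of fluoro on an aromatic carbon, the same change as that from compound 3 to compound 1.

For compound 4 in this assay a step of about a 1.2-fold lower number from compound 2 to compound 4 (0.06 log units; within the scatter) is expected, resting on the step from compound 3 to compound 1 that gave a 1.2-fold lower number from compound 3 to compound 1 (0.07 log units; within the scatter). The estimate for compound 4 is 380 nM, expected to lie between 200 nM and 750 nM.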

Compound 4, half-maximal effective concentration: 324 nM
For compound 4 the middle estimate is 1.2-fold (0.07 log units) above the measured one; the range from low to high includes it.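

In this assay, hydrogen in place of fluoro on the aromatic carbon gave a 1.3-fold lower number from compound 2 to compound 4 (0.13 log units; within the scatter), so on this core the change leaves the number inside the usual variation of the measurement. Set beside the earlier step, the change reads the same on both cores, with no difference between them that the assay can resolve: the same change on two cores in this assay, a 1.2-fold lower number (0.07 log units; within the scatter) from compound 3 to compound 1 and a 1.3-fold lower number (0.13 log units; within the scatter) from compound 2 to compound 4, 1.1-fold (0.06 log units) apart, within the scatter of two such steps. This supports carrying the fluoro-to-hydrogen change between these two cores as a step too small to read, but it rests on two pairs only, gives no real direction for the change, and does not show that a step large enough to read would carry over in the same way.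

Fluoro and hydrogen are the only groups shown on this aromatic carbon, so the effect of a chloro, a methoxy, a nitrile or an amine there remains open on either core. Also open, as far as these compounds go, is whether any such replacement would give matching steps on the two cores.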